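This account rests on a few compounds, and the source may have more. Where it says the series, first, only, none or still open, it means among the compounds named here.

Measured compounds and their values:
compound 1 `CS(=O)(=O)Nc1ccc2c(c1)S(=O)(=O)N=C(C1=C(O)C3CCCC3N(Cc3ccccn3)C1=O)N2` — > 1 h
compound 2 `CS(=O)(=O)Nc1ccc2c(c1)S(=O)(=O)N=C(C1=C(O)[C@H]3CCC[C@H]3N(Cc3ccc(F)c(F)c3)C1=O)N2` — > 1 h
compound 3 `CS(=O)(=O)Nc1ccc2c(c1)S(=O)(=O)N=C(C1=C(O)C3CCCCC3N(Cc3ccc(F)cc3)C1=O)N2` — > 1 h

The account follows the step from compound 2 to compound 4, with the shared core held fixed and only the group on the pendant benzyl ring changed. In an in vitro ADME assay on microsomes from liver (Homo sapiens) for metabolic stability (a lower number here means that the compound disappears faster, a higher number that the compound lasts longer), compound 2 gives > 1 h, which is a limit of the assay rather than a number. Compound 1 gives > 1 h in this assay, again a limit. Compound 3 likewise gives > 1 h in this assay, also a limit. Within the data shown here, compound 2 therefore stands where every other measured compound stands, namely at the limit of > 1 h in this assay, at which 3 of the 3 values shown sit; no measured compound sits anywhere else, and no step between measured compounds can be sized.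

Compound 4 `CS(=O)(=O)Nc1ccc2c(c1)S(=O)(=O)N=C(C1=C(O)[C@H]3CCC[C@H]3N(Cc3ccc(F)c(Cl)c3)C1=O)N2` is the unmeasured compound. It differs from compound 2 as follows: chloro in place of fluoro on an aromatic carbon. Among the measured compounds shown here, the change is small, and no measured pair in this set shows the effect of any change on the benzyl ring in this assay, since compound 1 and compound 3 also vary in the saturated ring fused to the core.

Without a measured step, the expectation for this assay is no step beyond the scatter in either direction. Compound 4 is therefore expected to give about 1.5 h in this assay, with a range from 0.6 h to 4 h, which amounts to an expected step that the limit leaves unreadable from compound 2 to compound 4.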

Compound 4, half-life: > 1 h
Compound 4: a limit, no number; the forecaster's own chance of this, stated with the estimate: 75%; the middle value lies beyond the limit too.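

In this assay compound 4 gives > 1 h as a limit of the assay and not a number. Compound 2 sits at the same limit, so no step from compound 2 to compound 4 can be read: the limit of > 1 h in this assay, at which 4 of the 4 values shown sit. The compounds shown leave open how far any of them lasts beyond that limit, and whether chloro in place of fluoro changes the half-life at all.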